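The source may hold more compounds than are shown below. What is called first, only, known or untested is meant among the compounds shown, and "the series" means these compounds.

Measured compounds:
- Compound 1 `Nc1ccc(-c2cnc(C(=O)CCCCCCc3ccccc3)o2)cc1` in an assay (Rattus norvegicus) for inhibition of Fatty-acid amide hydrolase 1 (Homo sapiens) (on this read-out lower numbers stand for stronger inhibition and higher numbers for weaker inhibition), gives 90 nM.
- Compound 2 `Cc1cccc(-c2cnc(C(=O)CCCCCCc3ccccc3)o2)n1` in this assay gives 3.3 nM.

Among the measured compounds shown here, compound 2 holds the lower of the two numbers measured so far; the only measured neighbor, compound 1, sits at a distance of a 27-fold lower number from compound 1 to compound 2 (1.44 log units; beyond the scatter). That single step exchanges the whole aryl group, not a substituent on it, so it does not bear directly on the change now considered. Compound 3 `NC(=O)c1cccc(-c2cnc(C(=O)CCCCCCc3ccccc3)o2)n1` differs from compound 2 by carbamoyl in place of methyl on an aromatic carbon. With no measured step of this kind in the set, the expectation rests on the observation that compound 2 already carries the best number and that the aryl portion responds strongly to change, as the step from compound 1 to compound 2 shows. Compound 3 is therefore expected to give a modestly higher number in this assay, a step of a 2.4-fold higher number from compound 2 to compound 3 (0.38 log units; beyond the scatter). The estimate for compound 3 is 8 nM, within 1.5 nM to 40 nM.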

Compound 3, inhibition constant: 1 nM
Compound 3: middle estimate off by 8.0-fold (0.90 log units), on the high side; measured number outside the range, below it.
By their numbers in this assay, from the lowest: compound 3; then compound 2; then compound 1.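

In this assay, the place next to the ring nitrogen accepts more than a methyl: carbamoyl in place of methyl gives a 3.3-fold lower number from compound 2 to compound 3 (0.52 log units; beyond the scatter) and so goes with a lower number, beyond the scatter. Exchanging the whole aryl group, 6-carbamoylpyridin-2-yl in place of 4-aminophenyl gives a 90-fold lower number from compound 1 to compound 3 (1.95 log units; beyond the scatter), which leaves compound 3 with the lowest of the three numbers, its steps to both others lying beyond the scatter. Nothing at hand speaks to the reason for these steps.

Still open, on these data alone, is whether the lower number needs the whole carbamoyl group or would also come with a nitrile, a methyl ester or a carboxylic acid at this place. Also open, as far as these compounds go, is whether the same step holds with a shorter chain on the carbonyl.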